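A few compounds are considered here, and "the series" means these few. Any claim that something is new, unique, unknown or untested is made for them only; others in the source may bear on it.

Within the data shown here, compound 3 `COc1ncnc2c1c(-c1ccoc1)cn2[C@@H]1O[C@H](CO)[C@@H](O)[C@H]1O` stands at the lowest of the two numbers so far in a functional assay on A549 cells (Homo sapiens), read by MTT assay, with a stated time of 72 h (a higher number here means a weaker inhibitor, a lower number a stronger inhibitor), where compound 3 gives 1160 nM. Compound 2 `COc1ncnc2c1c(-c1cc3ccccc3o1)cn2[C@@H]1O[C@H](CO)[C@@H](O)[C@H]1O` gives 17700 nM in this assay. Compound 1 `COc1ncnc2c1c(I)cn2[C@@H]1O[C@H](CO)[C@@H](O)[C@H]1O` gives > 20000 nM in this assay, which is a limit of the assay (the limit of > 20000 nM in this assay, at which 1 of the 3 values shown sits). The measured steps all change the group on the other ring position: a 15-fold lower number from compound 2 to compound 3 (1.18 log units; beyond the scatter), an at least 17-fold lower number from compound 1 to compound 3 (1.23 log units; beyond the scatter) and an at least 1.1-fold lower number from compound 1 to compound 2 (0.05 log units; that floor lies within the scatter).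

Compound 4 `CSc1ncnc2c1c(-c1ccoc1)cn2[C@@H]1O[C@H](CO)[C@@H](O)[C@H]1O` differs from compound 3 only in methylsulfanyl in place of methoxy on an aromatic carbon. Among the measured compounds shown here, no measured step touches the methoxy, so nothing speaks for or against a change on swapping it for methylsulfanyl. The steps that are known sit on a different position and give no guide here. The expected step is a 1.0-fold higher number from compound 3 to compound 4 (0.01 log units; within the scatter), that is, none beyond the scatter in this assay. For compound 4 the expected value in this assay is 1200 nM, with a range from 400 nM to 3600 nM.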

Compound 4, half-maximal inhibitory concentration: 280 nM
For compound 4 the middle estimate is 4.3-fold (0.63 log units) above the measured one; the whole stated range lies above it.
By their numbers in this assay, from the lowest: compound 4; then compound 3; then compound 2. At a limit, above all of these: compound 1.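

Methylsulfanyl in place of methoxy gives a 4.1-fold lower number from compound 3 to compound 4 (0.62 log units; beyond the scatter) in this assay and is the only measured step at this position, so the group on the aromatic carbon next to the ring nitrogen does affect the number. The step is smaller than a 15-fold lower number from compound 2 to compound 3 (1.18 log units; beyond the scatter) on the other ring position, but it shows that the two positions can both shift the read-out of the series. Nothing shown here bears on the cause of the methoxy to methylsulfanyl step.

From the compounds shown here alone, whether the lower number is specific to methylsulfanyl remains open: ethylsulfanyl or an amine such as dimethylamino at this position would test that. Going by these compounds, it is also open whether the step carries over to the iodo or 1-benzofuran-2-yl compounds, as this pair holds furan-3-yl fixed.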